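Bromo to Chloro on the Aromatic Ring

The source may report more compounds than this note shows. Statements on the series, on what has been measured and on what is new or still open speak of the compounds shown alone.

Compound 1, `COc1cc(NC(C)CCCNC(=O)NNC(=O)Nc2ccc(Br)cc2)c2ncccc2c1`: 100 nM in a functional assay on MCF7 cells (Homo sapiens) for inhibition, read by MTT assay, with a stated time of 72 h; a higher number here means a weaker inhibitor, a lower number a stronger inhibitor
Compound 2, `COc1cc(NC(C)CCCNC(=O)Nc2cccc(F)c2)c2ncccc2c1`: 18000 nM

Going by the values given here, compound 1 has the lower of the two numbers measured in this assay; its nearest neighbour is compound 2, and the only measured step, a 180-fold higher number from compound 1 to compound 2 (2.26 log units; beyond the scatter), is large and concerns a different part of the molecule. Compound 3, `COc1cc(NC(C)CCCNC(=O)NNC(=O)Nc2ccc(Cl)cc2)c2ncccc2c1`, has not yet been measured. It differs from compound 1 by chloro in place of bromo on an aromatic carbon, sitting on an aromatic carbon of a six-membered aromatic ring of carbon only, para to a large group. Among the compounds with values here, no measured step exchanges one halogen for another, so the step to compound 2 does not bear directly on this exchange; it shows only how far the number can move when the group on the amide-type nitrogen is replaced. Within the data shown here, with no comparable step in hand, the expected change for compound 3 is a 1.3-fold higher number from compound 1 to compound 3 (0.11 log units; within the scatter), which is not beyond the scatter. Compound 3 is therefore estimated at 130 nM, within 50 nM to 400 nM.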

Compound 3, half-maximal inhibitory concentration: 180 nM
Estimate against measurement, compound 3: 1.4-fold (0.14 log units) below; measured number inside the range.
By their numbers in this assay, from the lowest: compounds 1 and 3 (each within the scatter of the next); then compound 2.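

In this assay, the place para to a large group on the six-membered aromatic ring takes either halogen: there is a 1.8-fold higher number from compound 1 to compound 3 (0.26 log units; within the scatter) for chloro in place of bromo, so this exchange does not separate the two compounds. The large step seen earlier with bromo also appears with chloro, with a 100-fold lower number from compound 2 to compound 3 (2.00 log units; beyond the scatter) when ((4-chlorophenyl)carbamoyl)amino replaces 3-fluorophenyl on the amide-type nitrogen, and so it does not depend on which of the two halogens is present. No measurement at hand offers a reason for either step.

The compounds shown leave open whether a hydrogen, a methoxy group or a trifluoromethyl group at this same place would fall within the scatter of these two halogens. They also leave open how the number responds to a longer chain between the shared core and the urea-bearing end.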